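The source may report more compounds than this note shows. Statements on the series, on what has been measured and on what is new or still open speak of the compounds shown alone.

Measured so far in a functional assay on A-375 cells (Homo sapiens) for inhibition, read by CCK-8 assay, with a stated time of 72 h, tested at 2 uM; on this read-out higher numbers stand for more inhibition of growth at the one concentration tested and lower numbers for less inhibition of growth: compound 1 `Nc1ccccc1NC(=O)/C=C/c1ccc(CSc2cccc(F)c2)cc1` gives 6.75%, compound 2 `CCc1ccc(SCc2ccc(/C=C/C(=O)Nc3ccccc3N)cc2)cc1` gives 5.27%, and compound 3 `CCc1ccc(SCc2ccc(C(=O)Nc3ccccc3N)cc2)cc1` gives 19.6%.

Compound 1 and compound 2 share one core, while compound 3 carries a different core; the difference between the two cores is not broken down here. Among the three, compound 3 stands highest, its nearest neighbour being compound 1. Within the first pair, the change 3-fluorophenyl in place of 4-ethylphenyl on a sulfur gave a step of a number 1.5 percentage points higher from compound 2 to compound 1 (within the scatter).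

Compound 4 `Nc1ccccc1NC(=O)c1ccc(CSc2cccc(F)c2)cc1` is not yet measured. It arises from compound 3 by the same change, (3-fluorophenyl in place of 4-ethylphenyl on a sulfur), made on the same sulfur. In this assay compound 4 is expected to sit close to compound 3, with a step of a number 1.4 percentage points higher from compound 3 to compound 4 (within the scatter), because the step of a number 1.5 percentage points higher from compound 2 to compound 1 (within the scatter) was small. The estimate for compound 4 is 21%, expected to fall between 8% and 34%.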

Compound 4, percent growth inhibition at one concentration: 37.7%
Compound 4: the middle estimate sits 16.7 percentage points below what was measured; the measured number lies above the stated range.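

On the core of compound 3, putting 3-fluorophenyl in place of 4-ethylphenyl on the sulfur gave a step of a number 18.1 percentage points higher from compound 3 to compound 4 (beyond the scatter) in this assay. The size of this step did not carry over from one core to the other: the same change on two cores in this assay, a number 1.5 percentage points higher (within the scatter) from compound 2 to compound 1 and a number 18.1 percentage points higher (beyond the scatter) from compound 3 to compound 4, 16.6 percentage points apart, beyond the scatter of two such steps

This shows that the effect of the change depended on the core in these two pairs, but it does not show why, or how the change would behave on any further core. The compounds shown leave open what an unsubstituted phenyl, or a ring carrying an amine or a carboxylic acid, would do on the same sulfur. They also do not separate the part played by adding the fluorine from the part played by losing the ethyl.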